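The source may report more compounds than this note shows. Statements on the series, on what has been measured and on what is new or still open speak of the compounds shown alone.

Compound 1, with the structure `CSc1ccccc1N1CCN(CCCCCC(=O)N2CCc3ccccc3C2)CC1`, is measured in an assay on HEK293 cells for displacement of a labelled ligand from 5-hydroxytryptamine receptor 7 (Rattus norvegicus) (on this read-out lower numbers stand for stronger inhibition and higher numbers for weaker inhibition), where it gives 32.9 nM. Of the two compounds measured, compound 1 shows the highest number; its nearest neighbour is compound 2, with the structure `O=C(CCCCCN1CCN(c2ccccc2-c2ccccc2)CC1)N1CCc2ccccc2C1`, which gives 3.81 nM. Going by the values given here, the only measured step, an 8.6-fold lower number from compound 1 to compound 2 (0.94 log units; beyond the scatter), concerns a change on the aromatic ring of the arylpiperazine end, not the amide end.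

Compound 3, with the structure `CSc1ccccc1N1CCN(CCCCCC(=O)NCc2ccc(C#N)cc2)CC1`, is not yet measured. It differs from compound 1 at the carbonyl carbon: (4-cyanobenzyl)amino in place of 1,2,3,4-tetrahydroisoquinolin-2-yl on a carbonyl carbon. Among the compounds with values here, no measured step touches that part of the shared core, so the direction of the change rests on no direct precedent, and a moderate weakening is assumed for compound 3 as a working guess. The step of a 1.8-fold higher number from compound 1 to compound 3 (0.26 log units; within the scatter) is therefore expected. Compound 3 is estimated at 60 nM, in a range from 15 nM to 250 nM.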

Compound 3, inhibition constant: 9 nM
Compound 3: the middle estimate sits 6.7-fold (0.82 log units) above what was measured, outside the stated range (below it).
By their numbers in this assay, from the lowest: compound 2; then compound 3; then compound 1.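

In this assay, the carbonyl carbon proves to be a place where a change counts, not only the aromatic ring at the arylpiperazine end: (4-cyanobenzyl)amino in place of 1,2,3,4-tetrahydroisoquinolin-2-yl gives a 3.7-fold lower number from compound 1 to compound 3 (0.56 log units; beyond the scatter), a step beyond the scatter. The 1,2,3,4-tetrahydroisoquinolin-2-yl group is thus not needed for a number of this size, at least with methylsulfanyl on the aromatic ring. The entering group differs from the leaving one in its ring count, its triple bond and its hydrogen-bond donor and acceptor, and nothing available separates these features or explains the step.

On these data alone, it remains open whether the nitrile matters, which a plain benzylamino group or a methoxy group in its place could test. As far as these compounds go, it is also open whether the phenyl of compound 2 and the (4-cyanobenzyl)amino group of compound 3 would add up in one molecule.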